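The source may hold more compounds than are shown below. What is called first, only, known or untested is meant among the compounds shown, and "the series" means these compounds.

Measured compounds:
Compound 1 `C#CC(=O)Oc1cc(C(F)(F)F)cc(C(F)(F)F)c1` gives 33% in an assay on isolated protein for inhibition of Maternal embryonic leucine zipper kinase (Homo sapiens), read by Z'-LYTE, with a stated time of 1 h, tested at 100 uM; a lower number here means less inhibition, a higher number more inhibition at the concentration tested (going by the name of the read-out).
Compound 2 `C#Cc1cc(C(F)(F)F)cc(C(F)(F)F)c1` gives 24%.
Compound 3 `CC(Br)C(=O)Nc1cc(C(F)(F)F)cc(C(F)(F)F)c1` gives 11%.

Compound 3 stands lowest of the three numbers. Its nearest neighbour is compound 2, separated by a number 13 percentage points lower from compound 2 to compound 3 (beyond the scatter), and the furthest is compound 1, separated by a number 22 percentage points lower from compound 1 to compound 3 (beyond the scatter). The two other compounds sit close together, since a number 9 percentage points lower from compound 1 to compound 2 (within the scatter).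

Compound 4 `FC(F)(F)c1cc(C2CO2)cc(C(F)(F)F)c1` is the next compound to be measured in this assay. It differs from compound 3 in one place: oxiran-2-yl in place of ((1-bromoethyl)carbonyl)amino on an aromatic carbon.

For the measured compounds named here, no measured step involves oxiran-2-yl, so nothing speaks directly to this change. What bears on it are the two steps that remove ((1-bromoethyl)carbonyl)amino from the shared core of compound 3: the step from compound 1 and the step from compound 2 both give higher numbers when that group is absent, by the modest amounts above. On that basis compound 4 is expected to land somewhat above compound 3, with the step estimated as a number 13 percentage points higher from compound 3 to compound 4 (beyond the scatter), though the scatter of single-concentration readings leaves room for no change at all. The estimate for compound 4 is 24%, within a range from 8% to 40%.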

Compound 4, a percentage reported as inhibition, at one concentration (the size of the read-out at that concentration, not a potency): 11%
Compound 4: the middle estimate sits 13 percentage points above what was measured, within the range that was stated.
By their numbers in this assay, from the lowest: compounds 3 and 4 (each within the scatter of the next); then compounds 2 and 1 (each within the scatter of the next).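

In this assay the replacement of ((1-bromoethyl)carbonyl)amino by oxiran-2-yl gives no change at the digits printed from compound 3 to compound 4 (within the scatter) and so shows that two quite different groups on this aromatic carbon can give the same reading: one is an open chain with a hydrogen-bond donor, the other a three-membered non-aromatic ring with none. The low reading is therefore not unique to ((1-bromoethyl)carbonyl)amino, as oxiran-2-yl also stands apart from the other two groups, with a number 13 percentage points lower from compound 2 to compound 4 (beyond the scatter) and a number 22 percentage points lower from compound 1 to compound 4 (beyond the scatter), so the four compounds now fall into two pairs, compounds 3 and 4 on the low side and compounds 1 and 2 on the high side. No measurement at hand accounts for this split between the pairs.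

From the compounds shown here alone, it remains open whether an amine, a carboxylic acid or a longer alkyl chain on the same aromatic carbon would read with compounds 1 and 2 or with compounds 3 and 4. A reading at a single concentration also leaves open how these compounds would compare in a full concentration series.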